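The source may hold more compounds than are shown below. What is called first, only, known or untested is meant among the compounds shown, and "the series" means these compounds.

The study compares ureas built on one shared core and varied only in the aryl group attached to an amide-type nitrogen. In a functional assay on OVCAR-4 cells (Homo sapiens) for inhibition, read by sulforhodamine B assay, with a stated time of 48 h, tested at 1 uM (a lower number here means a stronger effect, a higher number a weaker effect of the compound at the concentration tested), compound 1 `COc1cc(Cl)cc(-c2nn(-c3cccc(NC(=O)Nc4cc(C(F)(F)F)cc(C(F)(F)F)c4)c3)cc2-c2ccncc2)c1` gives 30%. Compound 2 `COc1cc(Cl)cc(-c2nn(-c3cccc(NC(=O)Nc4ccc(Cl)c(Cl)c4)c3)cc2-c2ccncc2)c1` gives 83% in this assay, the higher of the two numbers measured, and its value lies well above that of compound 1, a gap beyond the usual scatter, so of the two it shows the weaker effect. Compound 3 `COc1cc(Cl)cc(-c2nn(-c3cccc(NC(=O)Nc4cccc(C(F)(F)F)c4)c3)cc2-c2ccncc2)c1` has not yet been measured. It differs from compound 2 in one place: 3-(trifluoromethyl)phenyl in place of 3,4-dichlorophenyl on an amide-type nitrogen. For the measured compounds named here, no step between two measured compounds covers this exact change. Going by the values given here, compound 1, with 30%, shows that an aryl group bearing trifluoromethyl can sit on this nitrogen with a low number, but its group is not the one entering compound 3, so the comparison is indirect. For compound 3 the expected step is a number 28 percentage points lower from compound 2 to compound 3 (beyond the scatter), downward, beyond the scatter, yet not reaching the value of compound 1. Compound 3 is therefore estimated at 55%, with a range from 25% to 85%.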

Compound 3, a percentage reported as activity, at one concentration (the size of the read-out at that concentration, not a potency): 71%
Compound 3: the middle estimate sits 16 percentage points below what was measured, and the stated range covers the measured number.
By their numbers in this assay, from the lowest: compound 1; then compound 3; then compound 2.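

In this assay, 3-(trifluoromethyl)phenyl in place of 3,4-dichlorophenyl on the amide-type nitrogen gives a number 12 percentage points lower from compound 2 to compound 3 (beyond the scatter) and so moves the read-out only modestly, though beyond the scatter, toward a stronger effect. The larger change comes from the number of trifluoromethyl groups on this aryl ring: hydrogen in place of trifluoromethyl on an aromatic carbon gives a number 41 percentage points higher from compound 1 to compound 3 (beyond the scatter) and so removes most of the strength seen with the doubly substituted ring, showing that a single trifluoromethyl group does not reproduce the low number of the ring bearing two. Nothing available here accounts for either step.

The compounds shown leave open whether the second trifluoromethyl group could be replaced by another substituent on the same ring, such as a single chlorine, a methoxy group, a nitrile or a carboxylic acid, and how such rings would compare with these three. They also do not tell whether the urea tolerates a non-aromatic group on this nitrogen, such as a cyclohexyl ring or a longer alkyl chain.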